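A Bromophenyl Swap on the Sulfonamide Nitrogen

The source may hold more compounds than are shown below. What is called first, only, known or untested is meant among the compounds shown, and "the series" means these compounds.

Of the compounds shown here, three sharing one core have been measured in a functional assay on MCF7 cells (Homo sapiens) for antiproliferative activity, read by MTT assay, with a stated time of 72 h; on this read-out higher numbers stand for weaker inhibition and lower numbers for stronger inhibition. Compound 1 (`CCN(c1ccc(C)cc1)S(=O)(=O)C1CC2OC1C(c1ccc(NC(=O)CCCCCCC(=O)O)cc1)=C2c1ccc(O)cc1`) gives 42300 nM, compound 2 (`CCN(c1cccc(C)c1)S(=O)(=O)C1CC2OC1C(c1ccc(NC(=O)CCCCCCC(=O)O)cc1)=C2c1ccc(O)cc1`) gives 31800 nM and compound 3 (`CCN(c1ccc(OC)cc1)S(=O)(=O)C1CC2OC1C(c1ccc(NC(=O)CCCCCCC(=O)O)cc1)=C2c1ccc(O)cc1`) gives 20300 nM. Compound 3 therefore sits at the low end of this small set, although only one of its two gaps exceeds the scatter: a 2.1-fold lower number from compound 1 to compound 3 (0.32 log units; beyond the scatter) does, while a 1.6-fold lower number from compound 2 to compound 3 (0.19 log units; within the scatter) does not. Compound 4 (`CCN(c1ccccc1Br)S(=O)(=O)C1CC2OC1C(c1ccc(NC(=O)CCCCCCC(=O)O)cc1)=C2c1ccc(O)cc1`) carries 2-bromophenyl in place of 4-methoxyphenyl on a sulfonamide nitrogen. The closest evidence is the set of ring changes already measured, and all are small. Moving the methyl group gave a 1.3-fold lower number from compound 1 to compound 2 (0.12 log units; within the scatter), and the one change beyond the scatter, a 2.1-fold lower number from compound 1 to compound 3 (0.32 log units; beyond the scatter), is modest and brought the methoxy group in. Among the measured compounds shown here, no measured compound carries bromine, so this remains an extrapolation. Losing the methoxy group may give back a little of that modest gain. The expected change is a 1.4-fold higher number from compound 3 to compound 4 (0.15 log units; within the scatter), an estimated shift that stays within the scatter. The estimate for compound 4 is 29000 nM, with an expected range from 13000 nM to 60000 nM.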

Compound 4, half-maximal inhibitory concentration: > 100000 nM
Compound 4: no number, only a limit (the forecaster's own chance of this, stated with the estimate: 3%); middle value at least 3.4-fold (0.53 log units) away from the limit.
By their numbers in this assay, from the lowest: compounds 3, 2 and 1 (each within the scatter of the next, the first and the last beyond it). At a limit, above all of these: compound 4.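

The earlier ring changes on this sulfonamide nitrogen moved the number only a little, but in this assay 2-bromophenyl gives a much larger shift, with an at least 4.9-fold higher number from compound 3 to compound 4 (0.69 log units; beyond the scatter), an at least 3.1-fold higher number from compound 2 to compound 4 (0.49 log units; beyond the scatter) and an at least 2.3-fold higher number from compound 1 to compound 4 (0.37 log units; beyond the scatter). Compound 4 gives only a limit and not a number, so each of these steps states only its smallest possible size: the limit of > 100000 nM in this assay, at which 1 of the 4 values shown sits. The swap changes both the group on the ring and its place on that ring, and these compounds cannot separate the two.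

As far as these compounds go, what 4-bromophenyl and 2-methylphenyl would give on this nitrogen stays open, and those two groups would help to tell the atom from its place. Also open, from the compounds shown here alone, is how a phenyl ring carrying an amine or a carboxylic acid would read here.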